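Replacing the thiadiazolylsulfanyl arm of compound 2 with an ethylpiperazine

The source may report more compounds than this note shows. Statements on the series, on what has been measured and on what is new or still open speak of the compounds shown alone.

The series shares one core carrying an amide-linked side arm. Compound 1 `Cn1c(-c2ccc(NC(=O)CSc3nc4ccccc4o3)cc2)nc(-c2ccccc2)c1-c1ccccc1` and compound 2 `Cc1nnc(SCC(=O)Nc2ccc(-c3nc(-c4ccccc4)c(-c4ccccc4)n3C)cc2)s1` are both measured in a functional assay on HT-29 cells (Homo sapiens) for cytotoxicity, read by MTT assay, with a stated time of 24 h, tested at 0.64 ug/mL; on this read-out lower numbers stand for a weaker effect and higher numbers for a stronger effect at the one concentration tested. In this assay compound 1 gives 24.8%, and in this assay compound 2 gives 34.8%. Among the compounds with values here, the only measured step, a number 10 percentage points higher from compound 1 to compound 2 (within the scatter), exchanges one aromatic group on the sulfur for another, so compound 2 and compound 1 cannot be told apart on these numbers.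

Compound 3 `CCN1CCN(CC(=O)Nc2ccc(-c3nc(-c4ccccc4)c(-c4ccccc4)n3C)cc2)CC1` has not been measured in this assay. It differs from compound 2 by 4-ethylpiperazin-1-yl in place of (5-methyl-1,3,4-thiadiazol-2-yl)sulfanyl on a saturated chain carbon bound to a carbonyl carbon. Within the data shown here, this change removes the sulfur and its aromatic ring altogether rather than exchanging one aromatic ring for another, so the single measured step bears on it only loosely: it shows that varying the group at this position left the read-out within the scatter, but it does not show what a saturated ring without sulfur does. Among the measured compounds shown here, compound 3 is therefore expected to give about 30%, between 10% and 55%, which means an expected step of a number 4.8 percentage points lower from compound 2 to compound 3 (within the scatter), with a wide range because no measured step covers this kind of change.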

Compound 3, a percentage reported as activity, at one concentration (the size of the read-out at that concentration, not a potency): 7.4%
Beside the measured number, compound 3's estimate is 22.6 percentage points above it; measured number outside the range, below it.
By their numbers in this assay, from the lowest: compound 3; then compounds 1 and 2 (each within the scatter of the next).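

In this assay, within the data shown here, the earlier pair showed only that exchanging one aromatic group on the sulfur for another left the read-out within the scatter, whereas this position now proves able to move it: the exchange gives a number 27.4 percentage points lower from compound 2 to compound 3 (beyond the scatter) and a number 17.4 percentage points lower from compound 1 to compound 3 (beyond the scatter) on the saturated chain carbon bound to a carbonyl carbon. Both steps replace a sulfur-linked aromatic ring with 4-ethylpiperazin-1-yl, a six-membered non-aromatic ring without sulfur, and both point the same way, so the lower number at the one concentration tested holds against either of the two sulfanyl arms. No measurement at hand accounts for this fall in the read-out.

As far as these compounds go, whether the lower number goes with the piperazine ring, with its ethyl group or with the absence of the sulfur and its aromatic ring stays open, as all of these change together in this one exchange. A morpholine or an unsubstituted piperazine on the same carbon, or a cyclohexylsulfanyl arm that keeps the sulfur but carries a saturated ring, would separate these possibilities.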